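The source may report more compounds than this note shows. Statements on the series, on what has been measured and on what is new or still open speak of the compounds shown alone.

Working notes on the series, cytotoxicity arm.

For the measured compounds named here, compound 2 `O=C1/C(=C/c2ccc(F)cc2)CN(S(=O)(=O)c2ccc(F)cc2)C/C1=C\c1ccc(F)cc1` is the weaker of the two compounds measured so far in a functional assay on HepG2 cells (Homo sapiens) for cytotoxicity, read by MTT assay, with a stated time of 24 h; a higher number here means a weaker inhibitor, a lower number a stronger inhibitor: compound 2 gives 8100 nM, the highest of the two numbers. Its nearest neighbour is compound 1 `O=C1/C(=C/c2ccc(F)cc2)CN(S(=O)(=O)c2ccc(C(F)(F)F)cc2)C/C1=C\c1ccc(F)cc1`, for which compound 1 gives 3200 nM. Going by the values given here, the only measured step in the set is a 2.5-fold higher number from compound 1 to compound 2 (0.40 log units; beyond the scatter), so the one position varied so far, the substituent on the sulfonyl-bearing ring, has moved the read-out by a modest amount.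

Compound 3 `N#Cc1ccc(S(=O)(=O)N2C/C(=C\c3ccc(F)cc3)C(=O)/C(=C/c3ccc(F)cc3)C2)cc1` changes that same position once more. The difference from compound 2 is cyano in place of fluoro on an aromatic carbon. Among the compounds with values here, only the step from compound 1 to compound 2 bears on it, and it was modest; no measured pair tells how a cyano behaves at this place, so the direction is open. The expectation is a step of modest size in this assay, most likely back toward the number of compound 1, giving an estimated step of a 1.6-fold lower number from compound 2 to compound 3 (0.21 log units; within the scatter). Compound 3 is therefore expected to give about 5000 nM, within a range of 1500 nM to 15000 nM.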

Compound 3, half-maximal inhibitory concentration: 9800 nM
Compound 3: middle estimate off by 2.0-fold (0.29 log units), on the low side; low and high end bracket the measured number.
By their numbers in this assay, from the lowest: compound 1; then compounds 2 and 3 (each within the scatter of the next).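

In this assay the exchange of (4-fluorophenyl)sulfonyl for (4-cyanophenyl)sulfonyl gives a 1.2-fold higher number from compound 2 to compound 3 (0.08 log units; within the scatter) and so, at this place, cyano and fluoro cannot be told apart, which the earlier pair could not show. Trifluoromethyl now stands apart from both other groups: the earlier step from fluoro is matched by a 3.1-fold higher number from compound 1 to compound 3 (0.49 log units; beyond the scatter) and compound 1 is the strongest of the three, although by modest margins only. Nothing available bears on why trifluoromethyl differs from fluoro and cyano at this place.

The three compounds leave open whether the lower number belongs to trifluoromethyl alone or would also appear with other groups at this position on the ring, such as a methoxy group, an amine or a carboxylic acid. They also leave open whether the same order would hold if the two 4-fluorophenyl groups of the shared core carried a different substituent, for example a chlorine atom or a methoxy group.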